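Moving one methyl group on an antiproliferative compound

A few compounds are considered here, and "the series" means these few. Any claim that something is new, unique, unknown or untested is made for them only; others in the source may bear on it.

Values measured in a functional assay on NCI-H460 cells (Homo sapiens) for antiproliferative activity, read by MTT assay, with a stated time of 48 h (a higher number here means a weaker inhibitor, a lower number a stronger inhibitor), follow
- compound 1 `COc1ccc(-c2nc3cccc(-c4cc(OC)c(OC)c(OC)c4)c3o2)cc1OC` gives > 25000 nM (a limit of the assay, not a number)
- compound 2 `COc1cc(-c2cccc3nc(-c4ccc(C)cc4)oc23)cc(OC)c1OC` gives 1900 nM (the only exact number so far)

Compound 3 `COc1cc(-c2cccc3nc(-c4cccc(C)c4)oc23)cc(OC)c1OC` differs from compound 2 only in where the methyl sits: 3-methylphenyl in place of 4-methylphenyl on an aromatic carbon with 3-methylphenyl in place of 4-methylphenyl on an aromatic carbon. For the measured compounds named here, the single measured step of an at least 13-fold lower number from compound 1 to compound 2 (1.11 log units; beyond the scatter) changed the group at this place and was large, but it swapped 3,4-dimethoxyphenyl for 4-methylphenyl rather than moving a methyl, so it sets no direction here. Only a small rise, probably within the scatter, is expected in this assay. The estimated change is a 1.6-fold higher number from compound 2 to compound 3 (0.20 log units; within the scatter) overall. For compound 3 the expected value is 3000 nM with an estimated range from 900 nM to 12000 nM.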

Compound 3, half-maximal inhibitory concentration: > 25000 nM
Compound 3: a limit, no number; the forecaster's own chance of this, stated with the estimate: 8%; middle value at least 8.3-fold (0.92 log units) away from the limit.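

In this assay, moving the methyl alone, with the same atoms joined differently, gives an at least 13-fold higher number from compound 2 to compound 3 (1.11 log units; beyond the scatter). So carrying a methylphenyl group at this place is not enough: of the two shown, only 4-methylphenyl gives an exact number. The step from compound 1 to compound 3 cannot be read, and the full size of the drop in activity stays unknown, since the reading stops at a limit: the limit of > 25000 nM in this assay, at which 2 of the 3 values shown sit.

On these data alone, whether an amine or a longer chain in place of the methyl of 4-methylphenyl would give an exact number remains open.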